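Removing one chloro from the 2,4-dichlorophenyl of compound 2

A few compounds are considered here, and "the series" means these few. Any claim that something is new, unique, unknown or untested is made for them only; others in the source may bear on it.

compound 1 `O=C(CCSc1nnc(-c2ccncc2)s1)Nc1ccc(Cl)cc1` — in an ADME assay on BHK-21 cells (Mesocricetus auratus) for cytotoxicity, with a stated time of 3 days (on this read-out lower numbers stand for higher toxicity in this test and higher numbers for lower toxicity in this test), compound 1 gives 8210 nM
compound 2 `O=C(CCSc1nnc(-c2ccncc2)s1)Nc1ccc(Cl)cc1Cl` — in this assay compound 2 gives only a limit, > 50000 nM

For compound 2 only the limit of > 50000 nM in this assay, at which 1 of the 2 values shown sits, is known, no number. Compound 3 `O=C(CCSc1nnc(-c2ccncc2)s1)Nc1ccccc1Cl` differs from compound 2 by hydrogen in place of chloro on an aromatic carbon. Going by the values given here, the single measured step that bears on this runs the opposite way: an at least 6.0-fold higher number from compound 1 to compound 2 (0.78 log units; beyond the scatter). Undoing a chloro addition of that kind is expected to bring the number back down, though the start point is itself a limit. A step of an at least 2.5-fold lower number from compound 2 to compound 3 (0.39 log units; beyond the scatter) is the estimate. Compound 3 is therefore expected at 20000 nM, within 6000 nM to 60000 nM.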

Compound 3, half-maximal cytotoxic concentration: > 50000 nM
Compound 3 was reported as a limit; the forecaster's own chance of this, stated with the estimate: 30%; middle value at least 2.5-fold (0.39 log units) from the limit.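

Going from 2,4-dichlorophenyl to 2-chlorophenyl does not bring the number back into a measurable range in this assay: compound 3 gives > 50000 nM, which is a limit and not a number. With 2-chlorophenyl in place of 4-chlorophenyl, the single chloro gives an at least 6.0-fold higher number from compound 1 to compound 3 (0.78 log units; beyond the scatter), so among the monochloro compounds shown, the lower number belongs to the 4-chlorophenyl. The step between compound 2 and compound 3 cannot be read because both rest on the same limit: the limit of > 50000 nM in this assay, at which 2 of the 3 values shown sit.

As far as these compounds go, how far compound 2 and compound 3 lie beyond that limit remains open. Also open, from the compounds shown here alone, is whether methoxy or an amine in place of the remaining chloro would keep the number at that limit.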